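A few compounds are considered here, and "the series" means these few. Any claim that something is new, unique, unknown or untested is made for them only; others in the source may bear on it.

Measured so far in a functional assay on SW480 cells (Homo sapiens) for cytotoxicity, read by MTT assay, with a stated time of 48 h; a higher number here means a weaker inhibitor, a lower number a stronger inhibitor:
compound 1 `COc1cc([C@@H]2C[C@@]2(CO)C(=O)Nc2ccccc2)cc(OC)c1OC`, 76800 nM
compound 2 `COc1cc([C@H]2C[C@@]2(CO)C(=O)Nc2ccccc2)cc(OC)c1OC`, > 100000 nM

Compound 2 stands at a limit of this assay: its reported value of > 100000 nM is the ceiling of the assay and not a number, as the limit of > 100000 nM in this assay, at which 1 of the 2 values shown sits, shows. Compound 1 gives 76800 nM in this assay. The step of an at least 1.3-fold higher number from compound 1 to compound 2 (0.11 log units; that floor lies within the scatter) is small; its floor is set by the limit of > 100000 nM in this assay, at which 1 of the 2 values shown sits, and the fact that compounds 1 and 2 differ only in the configuration as drawn shows that only the drawn configuration separates the two compounds.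

Compound 3 `COc1cc([C@H]2C[C@]2(CO)C(=O)Nc2ccccc2)cc(OC)c1OC` is not yet measured. It differs from compound 2 as follows: the two compounds have the same atoms and bonds and differ only in configuration as drawn: 1 of 2 stereo elements differ; a stereocentre at a saturated ring carbon is drawn R in compound 2 and S in compound 3. Among the measured compounds shown here, the only measured step that bears on a change of configuration alone is an at least 1.3-fold higher number from compound 1 to compound 2 (0.11 log units; that floor lies within the scatter), which did not reach beyond the scatter. A step of similar size, with no firm direction, is therefore expected for compound 3 in this assay. Compound 3 is expected to give 100000 nM in this assay, within 40000 nM to 250000 nM. This estimate for compound 3 means a step of a number no higher from compound 2 to compound 3 (the limit leaves the size open). A report of only a limit for compound 3 is about as likely as a number.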

Compound 3, half-maximal inhibitory concentration: > 100000 nM
Compound 3 was reported as a limit (the forecaster's own chance of this, stated with the estimate: 55%); the middle value lies on the limit itself.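

In this assay compound 3 gives > 100000 nM, which is a limit of the assay and not a number. Compound 3 is the mirror image of compound 1, and inverting both stereocentres gives an at least 1.3-fold higher number from compound 1 to compound 3 (0.11 log units; that floor lies within the scatter), so even this full change of configuration yields no step that can be read beyond the scatter: the fact that compounds 1 and 3 differ only in the configuration as drawn The step between compound 2 and compound 3, which changes one stereocentre, cannot be read because both compounds sit at the limit: the limit of > 100000 nM in this assay, at which 2 of the 3 values shown sit.

The limit hides how compound 2 and compound 3 truly compare, and whether either one differs from compound 1 by more than the scatter. On these data alone, what a different group on the shared core, such as an amine or a carboxylic acid, would do in this assay stays open, since these compounds vary configuration alone.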